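Chloro to nitro on two styryl sulfone cores

A few compounds are considered here, and "the series" means these few. Any claim that something is new, unique, unknown or untested is made for them only; others in the source may bear on it.

Measured so far, in a functional assay on DLD-1 cells (Homo sapiens) for antiproliferative activity, read by trypan blue exclusion; on this read-out lower numbers stand for stronger inhibition and higher numbers for weaker inhibition:
compound 1, `COc1cc(OC)c(/C=C/S(=O)(=O)Cc2ccc(Cl)cc2)c(OC)c1`, gives 15000 nM
compound 2, `COc1cc(OC)c(/C=C/S(=O)(=O)Cc2ccc([N+](=O)[O-])cc2)c(OC)c1`, gives 15000 nM
compound 3, `COc1ccc(CS(=O)(=O)/C=C/c2ccc(Cl)cc2)cc1`, gives 3000 nM

Compound 1 and compound 2 share one core and differ by nitro in place of chloro on an aromatic carbon; this gives no change at the digits printed from compound 1 to compound 2 (within the scatter). Compound 3 carries a second core; how the two cores differ is not broken down here, but in this assay compound 3 stands lowest of the three, beyond the scatter from both compound 1 and compound 2.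

Compound 4, `COc1ccc(CS(=O)(=O)/C=C/c2ccc([N+](=O)[O-])cc2)cc1`, is not yet measured. It differs from compound 3 by nitro in place of chloro on an aromatic carbon, the same change as from compound 1 to compound 2, at the same place.

Compound 4 is expected to show the step of no change at the digits printed from compound 3 to compound 4 (within the scatter) in this assay, resting on the earlier swap being flat because no change at the digits printed from compound 1 to compound 2 (within the scatter). Compound 4 is therefore estimated at 3000 nM, between 1500 nM and 6000 nM.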

Compound 4, half-maximal inhibitory concentration: 5000 nM
Beside the measured number, compound 4's estimate is 1.7-fold (0.22 log units) below it, and the stated range covers the measured number.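

In this assay nitro in place of chloro gives a 1.7-fold higher number from compound 3 to compound 4 (0.22 log units; within the scatter) on the second core, flat as on the first. Set side by side, the two steps do not differ: the same change on two cores in this assay, no change at the digits printed (within the scatter) from compound 1 to compound 2 and a 1.7-fold higher number (0.22 log units; within the scatter) from compound 3 to compound 4, 1.7-fold (0.22 log units) apart, within the scatter of two such steps. This supports carrying the swap between these two cores, but it rests on one pair per core and one aromatic carbon, and it does not show why the swap is flat or that it would hold on any further core.

As far as these compounds go, whether an amine or a carboxylic acid on the same aromatic carbon would also leave the number in place remains open. Other places on either core remain open too.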